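The source may report more compounds than this note shows. Statements on the series, on what has been measured and on what is new or still open speak of the compounds shown alone.

Measured so far in an ADME assay on microsomes from liver (Mus musculus) for metabolic stability, read by LC-MS, with a stated time of 30 min, tested at 0.1 uM; on this read-out lower numbers stand for a less stable compound and higher numbers for a more stable compound:
- Compound 1 `COc1cccc(Nc2cc3[nH]c(-c4cccc(C(F)(F)F)c4)nc3cn2)n1`: 60%
- Compound 2 `FC(F)(F)c1cccc(-c2nc3cnc(Nc4ccncn4)cc3[nH]2)c1`: 89%

Compound 2 stands highest of the two. Compound 3 `FC(F)(F)c1cccc(-c2nc3cnc(Nc4cnccn4)cc3[nH]2)c1` differs from it in one group: pyrazin-2-yl in place of pyrimidin-4-yl on a nitrogen on an aromatic ring. For the measured compounds named here, only one measured step bears on this change: a number 29 percentage points higher from compound 1 to compound 2 (beyond the scatter), modest and beyond the scatter, with pyrimidin-4-yl entering in place of 6-methoxypyridin-2-yl. The groups now exchanged resemble each other far more than those in that step did, so only a small drop, within the scatter, is expected in this assay. The expected step is a number 6 percentage points lower from compound 2 to compound 3 (within the scatter). Compound 3 is estimated at 83%, within a range of 66% to 96%.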

Compound 3, percent of the compound remaining: 7%
Compound 3: middle estimate off by 76 percentage points, on the high side, outside the stated range (below it).
By their numbers in this assay, from the lowest: compound 3; then compound 1; then compound 2.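

In this assay, this place on a nitrogen on an aromatic ring proves far more sensitive than the earlier pair could show, with a number 82 percentage points lower from compound 2 to compound 3 (beyond the scatter). Pyrazin-2-yl and pyrimidin-4-yl match in every count and differ only in how their atoms are joined, yet the other step, a number 53 percentage points lower from compound 1 to compound 3 (beyond the scatter), also leaves pyrazin-2-yl behind 6-methoxypyridin-2-yl. No measurement shown here accounts for this drop. The compounds shown leave open whether the low number belongs to pyrazin-2-yl as such, or whether a methyl group or an amine on that ring would change it.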